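Removing the methoxy from the brominated core

The compounds below may be only part of what the source reports. "The series", "measured", "known", "first", "only" and "open" are said of these compounds alone.

Compound 2 `COc1cc(Br)cc2c1OC(N)=C(C#N)C2CC(=O)c1ccc(C)cc1` gives 52.8% in a functional assay on MCF7 cells (Homo sapiens) for antiproliferative activity, read by sulforhodamine B assay, with a stated time of 72 h, tested at 30 uM; a lower number here means a stronger effect, a higher number a weaker effect of the compound at the concentration tested. Compound 1 `Cc1ccc(C(=O)CC2C(C#N)=C(N)Oc3ccc(Cl)cc32)cc1` gives 49% in this assay; the two values lie within the scatter of each other, so on the numbers shown compound 2 stands alongside compound 1 rather than apart from it. Compound 3 `Cc1ccc(C(=O)CC2C(C#N)=C(N)Oc3ccc(Br)cc32)cc1` is not yet measured. It differs from compound 2 in one place: hydrogen in place of methoxy on an aromatic carbon. Within the data shown here, no step between measured compounds is known for this change, so no shift beyond the scatter is expected in this assay from compound 2 to compound 3. Compound 3 is estimated at 50%, expected between 38% and 63%, a step of a number 2.8 percentage points lower from compound 2 to compound 3 (within the scatter).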

Compound 3, a percentage reported as activity, at one concentration (the size of the read-out at that concentration, not a potency): 32.3%
Beside the measured number, compound 3's estimate is 17.7 percentage points above it, outside the stated range (below it).
By their numbers in this assay, from the lowest: compound 3; then compounds 1 and 2 (each within the scatter of the next).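

In this assay hydrogen in place of methoxy gives a number 20.5 percentage points lower from compound 2 to compound 3 (beyond the scatter) on this aromatic carbon, so the position ortho to a fused ring responds to substitution. With no methoxy present, the halogen also counts: bromo in place of chloro gives a number 16.7 percentage points lower from compound 1 to compound 3 (beyond the scatter) on the shared core. Nothing at hand gives a reason for either step.

On these data alone, whether a hydroxy, an ethoxy or an amine on this carbon would match hydrogen or methoxy remains open. Also open, as far as these compounds go, is whether the halogen would count in the same way with the methoxy in place.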